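Swapping 2-chlorophenyl for 4-methylphenyl in a limit-only series

The compounds below may be only part of what the source reports. "The series", "measured", "known", "first", "only" and "open" are said of these compounds alone.

In a physicochemical assay for solubility, measured as kinetic solubility (on this read-out higher numbers stand for higher solubility and lower numbers for lower solubility), compound 3 `CNC(=O)c1cc(C(=O)N[C@H]2CC[C@H](O)CC2)c([C@@H](C)c2ccccc2Cl)o1` gives >= 242 ug/mL, which is a limit and not a number. Compound 1 `CNC(=O)c1cc(C(=O)N[C@H]2CC[C@H](O)CC2)c([C@@H](C)c2cccc(OC)c2)o1` gives >= 113 ug/mL, also a limit. Compound 2 `CNC(=O)c1cc(C(=O)N[C@H]2CC[C@H](O)CC2)c([C@@H](C)c2cccc(C)c2)o1` gives >= 172 ug/mL, again a limit. Among the compounds with values here, no compound in this set has a plain number in this assay, so compound 3 cannot be ranked against the other two.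

Compound 4 `CNC(=O)c1cc(C(=O)N[C@H]2CC[C@H](O)CC2)c([C@@H](C)c2ccc(C)cc2)o1` departs from compound 3 by one change: 4-methylphenyl in place of 2-chlorophenyl on a saturated chain carbon bound to an aromatic carbon and a saturated chain carbon. In words, this is 4-methylphenyl in place of 2-chlorophenyl on a saturated chain carbon bound to an aromatic carbon and a saturated chain carbon.

The closest measured change is a step that the two limits leave unreadable from compound 2 to compound 3, which also exchanges 2-chlorophenyl and a methylphenyl, though 3-methylphenyl rather than 4-methylphenyl. The other two comparisons, a step that the two limits leave unreadable from compound 1 to compound 2 and a step that the two limits leave unreadable from compound 1 to compound 3, give no size either. Within the data shown here, no measured step therefore supports a move in a particular direction, and no change beyond the usual scatter is expected. The expected change is an at least 1.2-fold lower number from compound 3 to compound 4 (0.08 log units; that floor lies within the scatter), an estimate only. The nearest guide is compound 2, whose >= 172 ug/mL is a limit. Another limit is the likely report for the new compound. For compound 4 the estimated value is 200 ug/mL, with an expected range of 100 ug/mL to 350 ug/mL.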

Compound 4, solubility: >= 245 ug/mL
Compound 4 ended at the assay's limit (the forecaster's own chance of this, stated with the estimate: 75%); middle value at least 1.2-fold (0.08 log units) away from the limit.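

In this assay compound 4 gives >= 245 ug/mL, which is a limit and not a number. The steps to compound 4 from compound 1, compound 2 and compound 3 cannot be read, as all four values are limits. The compounds shown leave open whether 2-chlorophenyl, 3-methoxyphenyl, 3-methylphenyl and 4-methylphenyl differ at all in solubility.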